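Exchanging 3-methoxyphenyl for 4-methoxyphenyl in the series

A few compounds are considered here, and "the series" means these few. Any claim that something is new, unique, unknown or untested is made for them only; others in the source may bear on it.

In a functional assay on MCF7 cells (Homo sapiens) for cytotoxicity, read by MTT assay, with a stated time of 24 h (a lower number here means a stronger inhibitor, a higher number a weaker inhibitor), compound 2 `COc1cccc(/C=C2\SC(=O)N(Cc3ccc(C(=O)O)cc3)C2=O)c1` gives 58000 nM and stands within the scatter of both other measured compounds. Compound 1 `O=C(O)c1ccc(CN2C(=O)S/C(=C\c3ccc(Br)cc3)C2=O)cc1` gives 48000 nM in the same test, and compound 3 `COc1cc(/C=C2\SC(=O)N(Cc3ccc(C(=O)O)cc3)C2=O)cc(OC)c1OC` gives 30000 nM there, so compound 2 is not separated from either.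

Compound 4 `COc1ccc(/C=C2\SC(=O)N(Cc3ccc(C(=O)O)cc3)C2=O)cc1` differs from compound 2 as follows: 4-methoxyphenyl in place of 3-methoxyphenyl on a double-bonded chain carbon bound to a double-bonded ring carbon with 4-methoxyphenyl in place of 3-methoxyphenyl on a double-bonded chain carbon bound to a double-bonded ring carbon.

Within the data shown here, the one measured step at this place is a 1.2-fold higher number from compound 1 to compound 2 (0.08 log units; within the scatter) and it stays within the scatter, although it exchanges 4-bromophenyl for 3-methoxyphenyl. Among the measured compounds shown here, no measured step compares the two methoxyphenyl groups directly. No step beyond the scatter is therefore expected in this assay and no direction is expected. The estimated change is a 1.3-fold lower number from compound 2 to compound 4 (0.11 log units; within the scatter) and remains within the scatter. For compound 4 the estimated value is 45000 nM with an expected range from 22000 nM to 90000 nM in this test.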

Compound 4, half-maximal inhibitory concentration: 48000 nM
The estimate for compound 4 lay 1.1-fold (0.03 log units) below the measured number, and the stated range covers the measured number.
By their numbers in this assay, from the lowest: compounds 3, 1, 4 and 2 (each within the scatter of the next).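

In this assay, among these compounds, the exchange of 3-methoxyphenyl for 4-methoxyphenyl on a double-bonded chain carbon bound to a double-bonded ring carbon gives a 1.2-fold lower number from compound 2 to compound 4 (0.08 log units; within the scatter) and so provides the first direct comparison of the two methoxyphenyl groups, which are not separated here. Methoxy in place of bromo on an aromatic carbon gives no change at the digits printed from compound 1 to compound 4 (within the scatter) and is likewise not separated, so neither the place of the methoxy group nor this exchange with bromo yet produces a step beyond the scatter in this series. No supporting measurement is available to interpret these results.

From the compounds shown here alone, whether an amine or a hydroxy group at this place would give a step beyond the scatter remains open. Also open, going by these compounds, is whether replacing the carboxylic acid with an amide would shift the number in this test.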